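The source may hold more compounds than are shown below. What is called first, only, known or untested is meant among the compounds shown, and "the series" means these compounds.

Compound 1 `OC[C@H]1O[C@@H](n2cnc3c(NCc4ccccc4Cl)ncnc32)[C@H](O)[C@@H]1O` — 14500 nM
Compound 2 `COc1ccccc1CNc1ncnc2c1ncn2[C@@H]1O[C@H](CO)[C@@H](O)[C@H]1O` — 3200 nM
Compound 3 `COc1cc(CNc2ncnc3c2ncn3[C@@H]2O[C@H](CO)[C@@H](O)[C@H]2O)cc(OC)c1` — a limit, > 166000 nM

The three measured compounds share a common core and differ only in the aryl group attached to the saturated chain carbon bound to a nitrogen on an aromatic ring. In a functional assay on CCRF-CEM cells (Homo sapiens) for antiproliferative activity, with a stated time of 72 h (on this read-out lower numbers stand for stronger inhibition and higher numbers for weaker inhibition), compound 1 gives 14500 nM, the higher of the two numbers that were actually resolved. Compound 2 gives 3200 nM, and the step is a 4.5-fold lower number from compound 1 to compound 2 (0.66 log units; beyond the scatter). For compound 3 the assay reports only a limit, > 166000 nM, so the step of an at least 11-fold higher number from compound 1 to compound 3 (1.05 log units; beyond the scatter) and the step of an at least 51-fold higher number from compound 2 to compound 3 (1.71 log units; beyond the scatter) are both read against (the limit of > 166000 nM in this assay, at which 1 of the 3 values shown sits).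

Compound 4 `OC[C@H]1O[C@@H](n2cnc3c(NCc4c(F)ccc(F)c4F)ncnc32)[C@H](O)[C@@H]1O` is not yet measured. It differs from compound 1 by 2,3,6-trifluorophenyl in place of 2-chlorophenyl on a saturated chain carbon bound to a nitrogen on an aromatic ring. Both measured steps bear on it: the change of the group at the single substituted position was modest, whereas the change to the 3,5-dimethoxyphenyl pattern was large and lost activity. Compound 4 keeps a substituent in the 2-position of the ring, so the expectation is a step within the scatter or a small one in either direction. The estimate for compound 4 is 12000 nM, between 4000 nM and 40000 nM, that is, an expected step of a 1.2-fold lower number from compound 1 to compound 4 (0.08 log units; within the scatter).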

Compound 4, half-maximal inhibitory concentration: 90300 nM
Compound 4: middle estimate off by 7.5-fold (0.88 log units), on the low side; the whole stated range lies below it.
By their numbers in this assay, from the lowest: compound 2; then compound 1; then compound 4. At a limit, above all of these: compound 3.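

In this assay, 2,3,6-trifluorophenyl in place of 2-chlorophenyl gives a 6.2-fold higher number from compound 1 to compound 4 (0.79 log units; beyond the scatter), which shows that a clear loss at this place is not confined to the 3,5-dimethoxyphenyl group. Set against the 2-methoxyphenyl group, the same aryl group gives a 28-fold higher number from compound 2 to compound 4 (1.45 log units; beyond the scatter), so this position separates even these two compounds widely. Compound 3 stands only at a limit, not a number, and the comparison with it gives no more than a floor, an at least 1.8-fold lower number from compound 3 to compound 4 (0.26 log units; that floor lies within the scatter): the limit of > 166000 nM in this assay, at which 1 of the 4 values shown sits.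

The compounds shown do not tell which of the three fluoro substituents carries the change, since a phenyl ring with a single fluoro group is not among them. Going by these compounds, it also remains open how an amine or a carboxylic acid on this phenyl ring would read out.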